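From a Hexyl Chain to a Larger Ring-Bearing Group

A few compounds are considered here, and "the series" means these few. Any claim that something is new, unique, unknown or untested is made for them only; others in the source may bear on it.

Among the compounds with values here, compound 2 `CCCCCCc1cn(Cc2cc(=O)oc3cc(O)ccc23)nn1` is the only compound of the two measured that gives a number in a functional assay on HeLa cells (Homo sapiens) for inhibition, read by MTT assay, with a stated time of 72 h; on this read-out lower numbers stand for stronger inhibition and higher numbers for weaker inhibition: compound 2 gives 59000 nM. Compound 1 `O=c1cc(Cn2cc(C3CC3)nn2)c2ccc(O)cc2o1` carries cyclopropyl where compound 2 carries hexyl. In this assay, within the data shown here, compound 1 reaches only a limit, > 100000 nM, and is the one value sitting at the limit of > 100000 nM in this assay, at which 1 of the 2 values shown sits. Among the measured compounds shown here, the single measured step, hexyl in place of cyclopropyl on an aromatic carbon, is an at least 1.6-fold lower number from compound 1 to compound 2 (0.22 log units; that floor lies within the scatter). Compound 3 `O=c1cc(Cn2cc(CSC(=S)N3CCNCC3)nn2)c2ccc(O)cc2o1` differs from compound 2 by a group of 9 heavy atoms (5 carbon, 2 nitrogen, 2 sulfur; one six-membered non-aromatic ring with 2 hetero atoms) in place of a group of 5 heavy atoms (5 carbon; no ring), on a saturated chain carbon bound to an aromatic carbon. For the measured compounds named here, the one measured step exchanged one hydrocarbon group for another and stayed at the floor of the scatter; it bears only loosely on a change that brings in a ring with hetero atoms and hydrogen-bonding atoms, so any step is expected to be modest and its direction uncertain. Compound 3 is therefore expected to give 30000 nM, between 5000 nM and 100000 nM, which is expected to mean a step of a 2.0-fold lower number from compound 2 to compound 3 (0.29 log units; within the scatter).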

Compound 3, half-maximal inhibitory concentration: > 100000 nM
Compound 3 was reported as a limit; the forecaster's own chance of this, stated with the estimate: 25%; middle value at least 3.3-fold (0.52 log units) from the limit.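

In this assay compound 3 gives > 100000 nM, which is a limit and not a number. From the compounds shown here alone, exchanging the pentyl for the larger ring-bearing group, on a saturated chain carbon bound to an aromatic carbon, gives an at least 1.6-fold higher number from compound 2 to compound 3 (0.22 log units; that floor lies within the scatter), so the ring with its hetero atoms and hydrogen-bond donor yields no number lower than that of compound 2, while the true size of the step stays unknown. Compound 2 remains the only compound shown with a number, and the ring-bearing group of compound 3 joins the cyclopropyl of compound 1 at the same limit: the limit of > 100000 nM in this assay, at which 2 of the 3 values shown sit.

Going by these compounds, whether a longer chain such as octyl or decyl would give a lower number than hexyl stays open. So does whether a simple amine on the same chain carbon, without the two sulfur atoms, would give a number at all.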